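Coumarin-aminopyrimidine series: aryl swap at the pyrimidine carbon

The compounds below may be only part of what the source reports. "The series", "measured", "known", "first", "only" and "open" are said of these compounds alone.

Measured so far in a functional assay on aorta (Rattus norvegicus, strain Wistar) for inhibition; on this read-out higher numbers stand for weaker inhibition and lower numbers for stronger inhibition:
- compound 1 `COc1ccc2ccc(=O)oc2c1-c1cc(-c2ccc(C)o2)nc(N)n1`: 1230000 nM
- compound 2 `COc1ccc2ccc(=O)oc2c1-c1cc(-c2cccs2)nc(N)n1`: 650000 nM; 1540000 nM (2 entries)
- compound 3 `COc1ccc2ccc(=O)oc2c1-c1cc(-c2ccc(SC)cc2)nc(N)n1`: 1140000 nM; 876000 nM (2 entries)

Going by the values given here, compound 1 is the only member of the set with a single entry in this assay; compounds 2 and 3 each return several entries, which sit within the usual scatter of one another the several entries of compound 2 in this assay, 650000 nM; 1540000 nM (2 entries) (the several entries of compound 3 in this assay, 1140000 nM; 876000 nM (2 entries)). Across all three compounds the numbers fall in the same region, and no pair of them is separated by a step that the scatter does not cover, so no order among them is claimed.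

Compound 4 `COc1ccc2ccc(=O)oc2c1-c1cc(-c2ccc([N+](=O)[O-])cc2)nc(N)n1` carries 4-nitrophenyl in place of 5-methylfuran-2-yl on an aromatic carbon. Among the compounds with values here, no step between measured compounds touches this position with a single change, so the expectation rests only on the flat picture given by compounds 1, 2 and 3. The step from compound 1 to compound 4 is expected to be small, in no fixed direction, and not beyond the scatter: a 1.1-fold lower number from compound 1 to compound 4 (0.05 log units; within the scatter). In this assay compound 4 is therefore estimated at 1100000 nM, with a range from 450000 nM to 2600000 nM.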

Compound 4, half-maximal inhibitory concentration: "not active" (no number reported)
For compound 4 the study gives words and no number, so the estimate cannot be set against anything.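

Going by these compounds alone, compound 4 is reported only in words as not active in this assay, so no step from compound 1 to compound 4 can be read, and nothing at hand bears on that result. The compounds shown leave open how far 4-nitrophenyl stands numerically from 5-methylfuran-2-yl.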